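Urea series on the shared core: aryl change to 2-chlorophenyl

The compounds below may be only part of what the source reports. "The series", "measured", "known", "first", "only" and "open" are said of these compounds alone.

Measured so far:
- compound 1 `COc1cccc(NC(=O)NC2CC(C)(C)Oc3ccc(Br)cc32)c1`: in a functional assay (aorta) with Rattus norvegicus as the target (a higher number here means that more compound is needed for the effect, a lower number that less compound is needed), compound 1 gives > 10000 nM, which is a limit of the assay.
- compound 2 `Cc1ccc(NC(=O)NC2CC(C)(C)Oc3ccc(Br)cc32)cc1`: in this assay compound 2 gives > 30000 nM, which is a limit of the assay.

Going by the values given here, compound 2 thus stands only as a limit in this assay, and the one other value, that of compound 1, is also a limit. The step that the two limits leave unreadable from compound 1 to compound 2 is accordingly not readable in size or direction.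

Compound 3 `CC1(C)CC(NC(=O)Nc2ccccc2Cl)c2cc(Br)ccc2O1` differs from compound 2 by 2-chlorophenyl in place of 4-methylphenyl on an amide-type nitrogen. Among the compounds with values here, no measured step involves a 2-chlorophenyl on the amide-type nitrogen; the only measured step, from 3-methoxyphenyl to 4-methylphenyl, left both ends at limits (the limit of > 10000 nM in this assay, at which 1 of the 2 values shown sits, and (the limit of > 30000 nM in this assay, at which 1 of the 2 values shown sits)), so nothing in the data points to a readable gain.

Compound 3 is therefore expected to stay at or near a limit in this assay, and the step of a number no higher from compound 2 to compound 3 (the limit leaves the size open) is estimated to be small. For compound 3 the estimate is 30000 nM, with a range from 5000 nM to 150000 nM.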

Compound 3, half-maximal effective concentration: > 30000 nM
Compound 3 was reported as a limit; the forecaster's own chance of this, stated with the estimate: 70%; the middle value lies on the limit itself.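

Compound 1, compound 2 and compound 3 each stand only as a limit in this assay, so the steps among them cannot be read in size or direction. The compounds shown leave open whether any group on the amide-type nitrogen of the shared core gives a measurable value in this assay.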